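Methoxy for Trifluoromethyl: One Step Measured, One Expected

This account rests on a few compounds, and the source may have more. Where it says the series, first, only, none or still open, it means among the compounds named here.

Compound 1 `O=C(O)c1cnc(-c2cccc(C(F)(F)F)c2)[nH]c1=O`: 33 mg/kg
Compound 2 `COc1cccc(-c2ncc(C(=O)O)c(=O)[nH]2)c1`: 10 mg/kg
Compound 3 `CCOC(=O)c1cnc(-c2ccc(C(F)(F)F)cc2)[nH]c1=O`: > 5 mg/kg

In a functional assay on the whole organism (strain Sprague-Dawley) for inhibition, with Rattus norvegicus as the target, with a stated time of 10 min (on this read-out lower numbers stand for an effect already at smaller amounts and higher numbers for an effect only at larger amounts of compound), compound 1 gives 33 mg/kg and compound 2 gives 10 mg/kg. The two differ only in methoxy in place of trifluoromethyl on an aromatic carbon, and this gave a 3.3-fold lower number from compound 1 to compound 2 (0.52 log units; beyond the scatter).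

Compound 3 carries a different core, and the difference between the two cores is not broken down here. In this assay compound 3 gives only a limit, > 5 mg/kg, and the limit of > 5 mg/kg in this assay, at which 1 of the 3 values shown sits, holds the place where it stands; no number is known for it.

Compound 4 `CCOC(=O)c1cnc(-c2ccc(OC)cc2)[nH]c1=O` is not yet measured. It differs from compound 3 in methoxy in place of trifluoromethyl on an aromatic carbon. Among the compounds with values here, this is the same kind of change as the one from compound 1 to compound 2, not the same: there the place was meta to a large group, here it is para to a large group.

Because the earlier change gave a 3.3-fold lower number from compound 1 to compound 2 (0.52 log units; beyond the scatter), a step of similar size, a step that the limit leaves unreadable from compound 3 to compound 4, is expected from compound 3 to compound 4, though the start is only a limit. Compound 4 is estimated at 8 mg/kg, between 3 mg/kg and 25 mg/kg.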

Compound 4, dose for 50% inhibition: 30 mg/kg
For compound 4 the middle estimate is 3.8-fold (0.57 log units) below the measured one; measured number above the stated range.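

No new step can be read between compound 3 and compound 4, since compound 3 has only a limit and no number in this assay: the limit of > 5 mg/kg in this assay, at which 1 of the 4 values shown sits.

The compounds shown leave open whether methoxy in place of trifluoromethyl, para to a large group, lowers the number as it does between compound 1 and compound 2.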